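Sulfonamide benzanilides: agonist efficacy at GPR27

This account rests on a few compounds, and the source may have more. Where it says the series, first, only, none or still open, it means among the compounds named here.

Measured compounds:
- compound 1, `O=C(NS(=O)(=O)c1ccc(NC(=O)c2ccc(Cl)cc2Cl)cc1)c1ccccc1`, result in a functional assay on HEK293 cells for agonist activity at probable G-protein coupled receptor 27 (Homo sapiens), read by a luciferase reporter and beta-arrestin recruitment, with a stated time of 10 min; a lower number here means a smaller maximal response, a higher number a larger maximal response: "not determined" (no result reported)
- compound 2, `O=C(Nc1ccc(S(=O)(=O)NCc2ccccc2)cc1)c1ccc(Cl)cc1Cl`, result in this assay: "not determined" (no result reported)
- compound 3, `Cc1cc(Cl)ccc1C(=O)Nc1ccc(S(=O)(=O)Nc2ccccc2)cc1`, this assay: 123%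

Compound 2 stands without a number in this assay; its entry reads "not determined" (no result reported), and compound 1 is in the same position with "not determined" (no result reported), so there is nothing to place compound 2 against. The only measured point in the series is compound 3, which in this assay gives 123%, a maximal response above that of the reference.

The step from compound 2 to compound 4, `O=C(Nc1ccc(S(=O)(=O)Nc2cccc(Cl)c2)cc1)c1ccc(Cl)cc1Cl`, consists of 3-chlorophenyl in place of benzyl on a sulfonamide nitrogen. The rest of the structure is unchanged. Within the data shown here, no measured pair shows this change, so its size and direction are not known from the data. Since compound 2 itself has no number, the expectation for compound 4 rests on compound 3 alone, which gives 123% and shares the core and the anilide pattern. A large maximal response in this assay is therefore expected for compound 4, with the width of the range reflecting the missing starting point.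

Compound 4 is estimated at 110%, between 70% and 150%.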

Compound 4, largest response reached (Emax), in percent of the reference or control that the assay uses: 40%
The estimate for compound 4 lay 70 percentage points above the measured number; measured number outside the range, below it.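

Among these compounds, compound 2 has no single number in this assay, so no step from compound 2 to compound 4 can be read. The compounds shown leave open how benzyl and 3-chlorophenyl on a sulfonamide nitrogen compare in maximal response. Nothing available bears on the value of compound 4.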